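Swapping the heteroaromatic group in a weakly active series

The source may hold more compounds than are shown below. What is called first, only, known or untested is meant among the compounds shown, and "the series" means these compounds.

Measured compounds in a functional assay on HeLa cells (Homo sapiens) for antiproliferative activity, read by MTT assay, with a stated time of 72 h; a lower number here means a stronger inhibitor, a higher number a weaker inhibitor:
Compound 1 `O=C1O/C(=C\Cn2cnc3c(F)nc(F)c(Cl)c32)C(OCc2ccccc2)=C1OCc1ccccc1` gives > 100000 nM, a limit of the assay.
Compound 2 `O=C1O/C(=C\Cn2cnc3c(Cl)c(F)nc(F)c32)C(OCc2ccccc2)=C1OCc1ccccc1` gives > 100000 nM, also a limit of the assay.
Compound 3 `O=C1NC(O)(CCn2cnc3ccn(CCC4(O)NC(=O)C(OCc5ccccc5)=C4OCc4ccccc4)c3c2=O)C(OCc2ccccc2)=C1OCc1ccccc1` gives 17000 nM; 18000 nM (2 entries).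

Compound 2 stands only at a limit in this assay, and no number is attached to it. Compound 1 is likewise known only as a limit, so the step that the two limits leave unreadable from compound 1 to compound 2 cannot be read. Within the data shown here, compound 3 is the one compound here with an actual number, and it sits at the weak end of what the assay resolves (the several entries of compound 3 in this assay, 17000 nM; 18000 nM (2 entries)); two of the three values shown are at the limit (the limit of > 100000 nM in this assay, at which 2 of the 3 values shown sit).

Compound 4 `O=C1O/C(=C\Cn2cnc3ncc(Br)c-3c2)C(OCc2ccccc2)=C1OCc1ccccc1` differs from compound 2 as follows: a group of 10 heavy atoms (6 carbon, 3 nitrogen, 1 bromine; one five-membered aromatic ring with 1 hetero atom, one six-membered aromatic ring with 2 hetero atoms) in place of a group of 12 heavy atoms (6 carbon, 3 nitrogen, 2 fluorine, 1 chlorine; one five-membered aromatic ring with 2 hetero atoms, one six-membered aromatic ring with 1 hetero atom), on a saturated chain carbon bound to a double-bonded chain carbon. Among the measured compounds shown here, no measured step bears on this change, since the only step with a related replacement is unreadable from its two limits. Compound 4 is therefore expected to remain near the limit, at about 100000 nM with a range from 30000 nM to 300000 nM. The implied step a number no higher from compound 2 to compound 4 (the limit leaves the size open) is an estimate without a readable precedent.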

Compound 4, half-maximal inhibitory concentration: 17000 nM
Compound 4: middle estimate off by 5.9-fold (0.77 log units), on the high side; the whole stated range lies above it.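

In this assay, the group on the saturated chain carbon bound to a double-bonded chain carbon proves able to move the read-out. Putting the group of 10 heavy atoms with bromine in place of the group of 12 heavy atoms with fluorine and chlorine gives an at least 5.8-fold lower number from compound 2 to compound 4 (0.76 log units; beyond the scatter), and the same kind of replacement gives an at least 5.8-fold lower number from compound 1 to compound 4 (0.76 log units; beyond the scatter). Among these compounds, the earlier exchange between the two groups of 12 heavy atoms could not be read, so these are the first readable changes at this place, and each gives only a minimum size.

The compounds shown leave open whether the bromine or the changed ring pair goes with the step, and how an amine or a chlorine in place of the bromine would read. Readable values also remain few in this set: the limit of > 100000 nM in this assay, at which 2 of the 4 values shown sit.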